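Swapping the Furan Substituent: From Nitrile to Difluoromethyl

A few compounds are considered here, and "the series" means these few. Any claim that something is new, unique, unknown or untested is made for them only; others in the source may bear on it.

Measured compounds:
compound 1, `Cc1ccc(-c2nc(N)c3cc(Cc4ccccc4)sc3n2)o1`, 298 nM
compound 2, `N#Cc1ccc(-c2nc(N)c3cc(Cc4ccccc4)sc3n2)o1`, 3160 nM

Among these two compounds, compound 2 holds the higher number in a functional assay on CHO-K1 cells for antagonist activity at adenosine receptor A1 (Homo sapiens), read by a beta-galactosidase reporter and cAMP accumulation, with stated times of 15 min and 6 h (on this read-out lower numbers stand for stronger inhibition and higher numbers for weaker inhibition), and its nearest neighbour is compound 1, which differs only in a methyl where compound 2 carries a cyano; that step, an 11-fold higher number from compound 1 to compound 2 (1.03 log units; beyond the scatter), is large and beyond the scatter. Compound 3, `Nc1nc(-c2ccc(C(F)F)o2)nc2sc(Cc3ccccc3)cc12`, has not yet been measured. It differs from compound 2 in one place: difluoromethyl in place of cyano on an aromatic carbon. For the measured compounds named here, only one measured step bears on this change, and it does so indirectly, since it exchanges methyl for cyano rather than cyano for difluoromethyl. The incoming group is neither of those two, so a step back toward the number of compound 1 is expected, though not all the way. The estimate for compound 3 is 900 nM, within 250 nM to 3500 nM, meaning an expected step of a 3.5-fold lower number from compound 2 to compound 3 (0.55 log units; beyond the scatter).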

Compound 3, inhibition constant: 3000 nM
For compound 3 the middle estimate is 3.3-fold (0.52 log units) below the measured one, and the stated range covers the measured number.
By their numbers in this assay, from the lowest: compound 1; then compounds 3 and 2 (each within the scatter of the next).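

In this assay, cyano and difluoromethyl at this position cannot be told apart (a 1.1-fold lower number from compound 2 to compound 3 (0.02 log units; within the scatter)), so two groups with different atoms give numbers within the usual scatter of each other. Methyl is the group that stands apart: putting difluoromethyl in its place gives a clear shift (a 10-fold higher number from compound 1 to compound 3 (1.00 log units; beyond the scatter)), in the same direction as the earlier exchange of methyl for cyano, and compound 1 therefore keeps the lowest number of the three. Nothing shown here gives a reason for this result.

On these data alone, whether the lower number belongs to methyl alone remains open, as does how an ethyl or a methoxy group would behave at this position. Trifluoromethyl would also show whether adding a further fluorine to difluoromethyl changes the number at all.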